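The source may report more compounds than this note shows. Statements on the series, on what has been measured and on what is new or still open speak of the compounds shown alone.

Within the data shown here, compound 1 `Cn1nc2c(=O)n(CC3(O)CCN(Cc4ccc(-c5ccncc5)cc4Cl)CC3)cnc2c1-c1ccc(CN)cc1` carries the highest of the three numbers so far in an assay on isolated protein for inhibition of ubiquitin carboxyl-terminal hydrolase 7 (Homo sapiens), with stated times of 30 min and 2 h (a higher number here means a weaker inhibitor, a lower number a stronger inhibitor), giving 257 nM. Compound 2 `Cn1nc2c(=O)n(CC3(O)CCN(Cc4ccc(-c5ccco5)cc4Cl)CC3)cnc2c1-c1ccc(Cl)cc1` gives 143 nM in this assay, and compound 3 `Cn1nc2c(=O)n(CC3(O)CCN(Cc4ccc(-c5ccco5)cc4Cl)CC3)cnc2c1-c1ccc(C(N)=O)cc1` gives 80.8 nM. Among the measured compounds shown here, the one measured single-point step, a 1.8-fold lower number from compound 2 to compound 3 (0.25 log units; within the scatter), concerns a carbamoyl in place of a chloro on an aromatic carbon and sits within the scatter. Compound 4 `Cn1nc2c(=O)n(CC3(O)CCN(Cc4ccc(-n5cccn5)cc4Cl)CC3)cnc2c1-c1ccc(CN)cc1` differs from compound 1 in another way: 1H-pyrazol-1-yl in place of pyridin-4-yl on an aromatic carbon. For the measured compounds named here, no measured step touches this position, so nothing here bears directly on the change, and the expectation is a step no larger than the scatter in this assay, as a 1.0-fold lower number from compound 1 to compound 4 (0.01 log units; within the scatter). Compound 4 is therefore estimated at 250 nM, with a range of 100 nM to 650 nM.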

Compound 4, half-maximal inhibitory concentration: 233 nM
Beside the measured number, compound 4's estimate is 1.1-fold (0.03 log units) above it; the range from low to high includes it.
By their numbers in this assay, from the lowest: compounds 3, 2, 4 and 1 (each within the scatter of the next, the first and the last beyond it).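

In this assay, the first step shown at this position, on an aromatic carbon meta to a chloro group and para to a large group, replaces pyridin-4-yl with 1H-pyrazol-1-yl (a 1.1-fold lower number from compound 1 to compound 4 (0.04 log units; within the scatter)). A five-membered aromatic ring with 2 hetero atoms can therefore stand in for a six-membered aromatic ring with 1 hetero atom without a step beyond the scatter. No supporting data bear on this result.

Open, from the compounds shown here alone, is whether a non-aromatic group such as morpholine or a carboxylic acid at this position would stay equally close. Also open, going by these compounds, is whether the same exchange would hold with the chloro or carbamoyl groups of compound 2 and compound 3.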